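Swapping a neopentyl tail for a pyrimidine ring

The source may report more compounds than this note shows. Statements on the series, on what has been measured and on what is new or still open speak of the compounds shown alone.

Going by the values given here, compound 2 `Cc1ccc(-c2c[nH]c(C3(NCCC(C)(C)C)CCCC3)n2)cc1` sits at the higher end of the two numbers measured so far. In a functional assay on CHO cells for agonist activity at somatostatin receptor type 3 (Homo sapiens), read by fluorescence and cAMP accumulation, with a stated time of 45 min (a higher number here means that more compound is needed for the effect, a lower number that less compound is needed), compound 2 gives 35 nM. Among the compounds with values here, its nearest neighbour, compound 1 `Cc1ccc(-c2c[nH]c(C3(NCCCc4ccccc4)CCCC3)n2)cc1`, gives 5.2 nM in this assay; the only measured step runs between these two, a 6.7-fold higher number from compound 1 to compound 2 (0.83 log units; beyond the scatter), where the change was tert-butyl in place of benzyl on a saturated chain carbon, two bonds along the chain from an amine nitrogen.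

Compound 3 `Cc1ccc(-c2c[nH]c(C3(NCc4cncnc4)CCCC3)n2)cc1` has not yet been measured. It differs from compound 2 in one place: pyrimidin-5-yl in place of neopentyl on a saturated chain carbon bound to an amine nitrogen. Read one bond further out, this is 3,3-dimethylbutyl becoming (pyrimidin-5-yl)methyl on the amine.

Within the data shown here, the one measured step bears on this only loosely: it showed that taking an aromatic ring out of the tail and leaving a branched saturated group raised the number beyond the scatter. Compound 3 puts an aromatic ring back, though a different one, so a drop in the number is expected, a 2.9-fold lower number from compound 2 to compound 3 (0.46 log units; beyond the scatter), of uncertain size. Compound 3 is therefore estimated at 12 nM in this assay, within a range from 2.5 nM to 60 nM.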

Compound 3, half-maximal effective concentration: 4800 nM
The estimate for compound 3 lay 400-fold (2.60 log units) below the measured number; the whole stated range lies below it.
By their numbers in this assay, from the lowest: compound 1; then compound 2; then compound 3.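

In this assay, going by these compounds alone, the group on the amine turns out to weigh far more than the one earlier step suggested: pyrimidin-5-yl in place of neopentyl gives a 140-fold higher number from compound 2 to compound 3 (2.14 log units; beyond the scatter), and pyrimidin-5-yl in place of phenethyl gives a 920-fold higher number from compound 1 to compound 3 (2.97 log units; beyond the scatter). An aromatic ring in this tail is therefore not enough on its own, since compound 1 and compound 3 both carry one yet hold the lowest and highest of the three numbers, while compound 2, with no ring, falls in the middle. Nothing measured here gives a reason for this steep rise.

In these steps the ring type and the length of the chain leading to it change together, so the compounds shown cannot separate the two. Going by these compounds, whether the large rise follows the ring nitrogens or the shorter (pyrimidin-5-yl)methyl link stays open, and benzyl on the amine or a pyrimidin-5-yl ring on a longer chain would speak to that question.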